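This account rests on a few compounds, and the source may have more. Where it says the series, first, only, none or still open, it means among the compounds named here.

Measured so far in a functional assay on MCF7 cells (Homo sapiens) for antiproliferative activity, read by MTT assay, with a stated time of 72 h; a higher number here means a weaker inhibitor, a lower number a stronger inhibitor: compound 1 `CC/C=C/C(=O)Nc1cccc(Oc2nc(Nc3ccn(C)n3)nc3c2CSCC3)c1`, whose result is a limit of the assay, > 50000 nM. Compound 2 `CCC/C=C/C(=O)Nc1cccc(Oc2nc(Nc3ccn(C)n3)nc3c2CSCC3)c1` gives 22600 nM. Compound 3 `CC/C=C/C(=O)Nc1cccc(Oc2nc(Nc3ccc(OC)nc3)nc3c2CSCC3)c1` gives 31500 nM.

The change from compound 1 to compound 2 is methyl in place of hydrogen on a saturated chain carbon, two bonds along the chain from a double-bonded chain carbon. It brought an at least 2.2-fold lower number from compound 1 to compound 2 (0.34 log units; beyond the scatter); the step is known only as a floor because the limit of > 50000 nM in this assay, at which 1 of the 3 values shown sits, is where compound 1 sits. The two cores differ by 6-methoxypyridin-3-yl in place of 1-methyl-1H-pyrazol-3-yl on a nitrogen on an aromatic ring, which gave an at least 1.5-fold lower number from compound 1 to compound 3 (0.20 log units; that floor lies within the scatter). Compound 2 and compound 3 lie within the scatter of each other, so no order between them can be read.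

Compound 4 `CCC/C=C/C(=O)Nc1cccc(Oc2nc(Nc3ccc(OC)nc3)nc3c2CSCC3)c1` has not yet been measured. It differs from compound 3 by methyl in place of hydrogen on a saturated chain carbon, two bonds along the chain from a double-bonded chain carbon, the same change that was made from compound 1 to compound 2, at the same place. On the core of compound 3, compound 4 is expected to show a 2.3-fold lower number from compound 3 to compound 4 (0.35 log units; beyond the scatter), an expectation resting on the step of an at least 2.2-fold lower number from compound 1 to compound 2 (0.34 log units; beyond the scatter) seen on the other core. Compound 4 is therefore estimated at 14000 nM in this assay, with a likely range from 6000 nM to 35000 nM.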

Compound 4, half-maximal inhibitory concentration: 26800 nM
Compound 4: middle estimate off by 1.9-fold (0.28 log units), on the low side; the range from low to high includes it.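

In this assay, the methyl that turns but-1-en-1-yl into pent-1-en-1-yl gave a 1.2-fold lower number from compound 3 to compound 4 (0.07 log units; within the scatter), so on the core of compound 3 this change has no effect that can be told from the scatter, and it sits beside the earlier step as follows: the same change on two cores in this assay, an at least 2.2-fold lower number (0.34 log units; beyond the scatter) from compound 1 to compound 2 and a 1.2-fold lower number (0.07 log units; within the scatter) from compound 3 to compound 4; the limit leaves it open whether they differ. The exchange of 1-methyl-1H-pyrazol-3-yl for 6-methoxypyridin-3-yl, carried onto the pent-1-en-1-yl compounds, gave a 1.2-fold higher number from compound 2 to compound 4 (0.07 log units; within the scatter), which also stays within the scatter: the same change on two cores in this assay, an at least 1.5-fold lower number (0.20 log units; that floor lies within the scatter) from compound 1 to compound 3 and a 1.2-fold higher number (0.07 log units; within the scatter) from compound 2 to compound 4; the limit leaves it open whether they differ. This does not show that either change behaves differently on the two cores, because the result for compound 1 is a limit of the assay and not a number: the limit of > 50000 nM in this assay, at which 1 of the 4 values shown sits.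

The compounds shown leave open whether a longer chain than pent-1-en-1-yl would bring a step beyond the scatter on either core. They also leave open how a plain phenyl in place of the 6-methoxypyridin-3-yl on that nitrogen would read.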